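A Hydroxy Group Added to Compound 2

The source may hold more compounds than are shown below. What is called first, only, known or untested is meant among the compounds shown, and "the series" means these compounds.

Compound 1 `COc1ccc(/C=C/C(=O)c2ccccc2-c2ccc(F)cc2)cc1O`: 420 nM
Compound 2 `COc1ccc(/C=C/C(=O)c2ccccc2-c2cccc(F)c2)cc1`: 220 nM

In a functional assay on HCT-8 cells (Homo sapiens) for antiproliferative activity, read by sulforhodamine B assay, with a stated time of 48 h (on this read-out higher numbers stand for weaker inhibition and lower numbers for stronger inhibition), compound 2 gives 220 nM and stands within the usual scatter of compound 1 (420 nM), so these two numbers do not separate the compounds. Compound 3 `COc1ccc(/C=C/C(=O)c2ccccc2-c2cccc(F)c2)cc1O` has not yet been measured. It differs from compound 2 in one place (hydroxy in place of hydrogen on an aromatic carbon), with hydroxy in place of hydrogen on an aromatic carbon, ortho to a methoxy group and meta to a large group.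

Among the compounds with values here, no measured pair isolates this change, so the data give no direct size for it. Compound 1 also carries a hydroxy group, although it differs from compound 3 in where its fluoro group sits. Compound 1 gives 420 nM in this comparison, which offers only indirect guidance and does not suggest a large step. The expected change is a 1.3-fold lower number from compound 2 to compound 3 (0.11 log units; within the scatter) toward stronger inhibition, a small step that is not expected to go beyond the scatter. Compound 3 is estimated at 170 nM within an expected range of 50 nM to 550 nM on this measure.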

Compound 3, half-maximal inhibitory concentration: 57 nM
Beside the measured number, compound 3's estimate is 3.0-fold (0.47 log units) above it; low and high end bracket the measured number.
By their numbers in this assay, from the lowest: compound 3; then compounds 2 and 1 (each within the scatter of the next).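

In this assay, hydroxy in place of hydrogen on an aromatic carbon, ortho to a methoxy group and meta to a large group, now has a direct size: the change gives a 3.9-fold lower number from compound 2 to compound 3 (0.59 log units; beyond the scatter) toward stronger inhibition, a step that the earlier pair of compounds could not supply. Compound 3 also separates from the other hydroxy compound, since 3-fluorophenyl in place of 4-fluorophenyl on an aromatic carbon gives a 7.4-fold lower number from compound 1 to compound 3 (0.87 log units; beyond the scatter) with the hydroxy group present in both, so the place of the fluoro group matters among these hydroxy compounds, while compound 1 and compound 2 alone stood within the scatter of each other. Nothing available explains why either step occurs.

The compounds shown leave open whether an amine or a carboxylic acid on the same aromatic carbon would match the hydroxy group. They also leave open whether the step between the two fluorophenyl groups would appear without the hydroxy group, and whether the hydroxy step would be of similar size with 4-fluorophenyl in place of 3-fluorophenyl.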